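This account rests on a few compounds, and the source may have more. Where it says the series, first, only, none or still open, it means among the compounds named here.

Measured so far:
compound 1 `Cc1cc(C)cc(CN(C)C(=O)Nc2c(-c3ccccc3)c3cc(C)c(C)cc3c(=O)n2C)c1` — 28 nM
compound 2 `Cc1ccccc1-c1c(C(=O)NCc2cc(C(F)(F)F)cc(C(F)(F)F)c2)n(C)c(=O)c2ccccc12` — 2.5 nM
compound 3 `CN(Cc1ccccc1)C(=O)Nc1c(-c2ccccc2)c2ccccc2c(=O)n1C` — 110 nM

In an assay on IM-9 cells for binding affinity to Substance-P receptor (Homo sapiens) (a higher number here means a weaker inhibitor, a lower number a stronger inhibitor), compound 1 gives 28 nM, the second highest of the three numbers. Its nearest neighbour is compound 3, whose value 110 nM lies beyond the scatter above it; furthest away is compound 2, whose value 2.5 nM lies beyond the scatter below it. For the measured compounds named here, no single-change pair among the measured compounds is available to calibrate a step.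

Compound 4 `Cc1cc2c(-c3ccccc3)c(NC(=O)N(C)Cc3ccccc3)n(C)c(=O)c2cc1C` is not yet measured. It differs from compound 1 in one place: phenyl in place of 3,5-dimethylphenyl on a saturated chain carbon bound to an amide-type nitrogen. The change removes the two methyl groups of the 3,5-dimethylbenzyl and leaves a plain benzyl on the same chain carbon. Within this set, the only compound bearing a benzyl(methyl)amino arm, compound 3, gives the highest number, 110 nM, while the two compounds with substituted benzyl arms give the lower numbers. That is thin ground, but it points to a step in this assay toward a higher number, of a size beyond the scatter rather than within it.

For compound 4 the expected value is therefore 100 nM, within 40 nM to 300 nM, meaning an expected step of a 3.6-fold higher number from compound 1 to compound 4 (0.55 log units; beyond the scatter).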

Compound 4, half-maximal inhibitory concentration: 16 nM
Compound 4: the middle estimate sits 6.3-fold (0.80 log units) above what was measured; measured number below the stated range.
By their numbers in this assay, from the lowest: compound 2; then compounds 4 and 1 (each within the scatter of the next); then compound 3.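

In this assay, removing the methyl groups of the 3,5-dimethylphenyl on the saturated chain carbon bound to an amide-type nitrogen gives a 1.8-fold lower number from compound 1 to compound 4 (0.24 log units; within the scatter), so on the core of compound 1 this position accepts phenyl and 3,5-dimethylphenyl without a step that can be told from repeat scatter. For the compounds shown here, the plain benzyl therefore does not by itself carry a high number, which the earlier compounds, with no single-change pair among them, could not show. No measurement is at hand that bears on why the methyl groups leave the number within the scatter, and the step alone gives no explanation.

Still open, on these data alone, is whether this tolerance extends to other groups at the same place, such as chloro or methoxy in place of the methyl groups on the ring, or a longer chain in place of the single chain carbon. As far as these compounds go, it is also open whether the same change would read alike on a core lacking the methyl groups that compound 1 and compound 4 share.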